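Compound 3 to compound 4: 4-phenylphenyl to 4-fluorophenyl

The source may hold more compounds than are shown below. What is called first, only, known or untested is meant among the compounds shown, and "the series" means these compounds.

Within the data shown here, in a functional assay on HepG2 cells (Homo sapiens) for inhibition, read by MTT assay, with a stated time of 24 h (a lower number here means a stronger inhibitor, a higher number a weaker inhibitor), compound 1 (`COc1ccc(/C=N/NC(=O)CNC(=O)c2ccc(F)cc2)c(OCc2ccccc2Cl)c1`) gives 15700 nM as the only true number so far. Compound 2 (`CCN(CC)c1ccc(/C=N/NC(=O)CNC(=O)c2ccc(F)cc2)c(OCc2ccccc2Cl)c1`) reads > 50000 nM and this is a limit. Compound 3 (`O=C(CNC(=O)c1ccc(-c2ccccc2)cc1)N/N=C/c1ccccc1OCc1ccccc1Cl`) reads > 50000 nM and this too is a limit. Among the measured compounds shown here, compound 3 therefore has no number of its own, and the series so far is bounded by the limit of > 50000 nM in this assay, at which 2 of the 3 values shown sit, in the notes on this stretch.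

The change fluoro in place of phenyl on an aromatic carbon leads to compound 4 (`O=C(CNC(=O)c1ccc(F)cc1)N/N=C/c1ccccc1OCc1ccccc1Cl`), with fluoro in place of phenyl on an aromatic carbon, para to a large group. For the measured compounds named here, no measured step covers this exchange. Going by the values given here, the one measured step is an at least 3.1-fold higher number from compound 1 to compound 2 (0.50 log units; beyond the scatter) and it lies at another place on the molecule, so it gives a sense of how far this assay can move but no direct reading for this change. The 4-fluorophenyl group is shared with compound 1 at 15700 nM as the only numeric anchor. A move towards a lower number is expected, of modest size and with wide uncertainty. The expected step is an at least 2.2-fold lower number from compound 3 to compound 4 (0.35 log units; beyond the scatter) and it remains an estimate. For compound 4 the estimated value is 22000 nM with an expected range from 8000 nM to 50000 nM and a real chance of only a limit again.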

Compound 4, half-maximal inhibitory concentration: 24900 nM
Compound 4: middle estimate off by 1.1-fold (0.05 log units), on the low side, within the range that was stated.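

In this assay, among these compounds, fluoro in place of phenyl on an aromatic carbon, para to a large group, gives an at least 2.0-fold lower number from compound 3 to compound 4 (0.30 log units; that floor lies within the scatter); this is the first reading at this position, and it turns a value that was only a limit into a true number, though the floor of the step does not by itself clear the usual scatter. At the other place on the molecule, hydrogen in place of diethylamino gives an at least 2.0-fold lower number from compound 2 to compound 4 (0.30 log units; that floor lies within the scatter), again with a floor that does not clear the scatter, while hydrogen in place of methoxy gives a 1.6-fold higher number from compound 1 to compound 4 (0.20 log units; within the scatter), so methoxy and hydrogen are not told apart there in this assay. The full size of the phenyl and diethylamino steps cannot be stated because both of those compounds sit at the limit of the assay: the limit of > 50000 nM in this assay, at which 2 of the 4 values shown sit.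

Going by these compounds, whether chloro, an amine or a carboxylic acid in the place of the fluoro would give a true number or another limit remains open. Equally open, on these data alone, is whether dimethylamino in the place of diethylamino would stay at the limit or return a true number.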